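The source may report more compounds than this note shows. Statements on the series, on what has been measured and on what is new or still open speak of the compounds shown alone.

Working notes on the series. Three compounds have numbers in a functional assay on A549 cells (Homo sapiens) for inhibition, read by sulforhodamine B assay, with a stated time of 72 h; on this read-out higher numbers stand for weaker inhibition and lower numbers for stronger inhibition. Compound 1 `Nc1sc(-c2ccc(Cl)cc2)c(-c2ccc(Cl)cc2)c1C(=O)NC1CCC(O)CC1` gives 250 nM. Compound 2 `CC(C)(C)NC(=O)c1c(N)sc(-c2ccc(Cl)cc2)c1-c1ccc(Cl)cc1` gives 8850 nM, the second highest of the three; compound 3 `CCOC(=O)Nc1sc(-c2ccc(Cl)cc2)c(-c2ccc(Cl)cc2)c1C(=O)NC1CC1` gives 39800 nM.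

The step from compound 2 to compound 4 `Nc1sc(-c2ccc(Cl)cc2)c(-c2ccc(Cl)cc2)c1C(=O)N1CCNCC1` is piperazin-1-yl in place of (tert-butyl)amino on a carbonyl carbon. Among the measured compounds shown here, the one measured step that bears on it is a 35-fold higher number from compound 1 to compound 2 (1.55 log units; beyond the scatter), which shows that what sits on this carbonyl carbon moves the numbers far beyond the scatter. On that evidence a step beyond the scatter is expected here too, and the enters group carries a donor and an acceptor as the group of compound 1 does, so a lower number is expected, as a 3.5-fold lower number from compound 2 to compound 4 (0.55 log units; beyond the scatter). Compound 4 is therefore estimated at 2500 nM, within 400 nM to 15000 nM.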

Compound 4, half-maximal inhibitory concentration: 1020 nM
Compound 4: middle estimate off by 2.5-fold (0.39 log units), on the high side; low and high end bracket the measured number.
By their numbers in this assay, from the lowest: compound 1; then compound 4; then compound 2; then compound 3.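

In this assay a ring on this carbonyl carbon, with no amide hydrogen left, still brings the number down, an 8.7-fold lower number from compound 2 to compound 4 (0.94 log units; beyond the scatter), so low numbers here are not confined to the (4-hydroxycyclohexyl)amino group of compound 1. That group is not matched by piperazin-1-yl, however, with a 4.1-fold higher number from compound 1 to compound 4 (0.61 log units; beyond the scatter). No measurement on hand accounts for either step.

Going by these compounds, whether the second ring nitrogen of piperazin-1-yl matters remains open. Piperidin-1-yl, morpholin-4-yl or 4-methylpiperazin-1-yl on the same carbonyl carbon would test this.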